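Sulfanyl for phenyl on the oxadiazole-linked benzothiazole series

The source may hold more compounds than are shown below. What is called first, only, known or untested is meant among the compounds shown, and "the series" means these compounds.

Measured so far:
compound 1 `Clc1ccc2nc(Nc3nnc(-c4ccccc4)o3)sc2c1` — 78.8%
compound 2 `Clc1ccc(-c2nnc(Nc3nc4ccc(Cl)cc4s3)o2)c(Cl)c1` — 80%
compound 3 `Clc1ccc2nc(Nc3nnc(Oc4ccccc4)o3)sc2c1` — 74.2%

In a functional assay on the whole organism (strain Wistar) for inhibition, with Rattus norvegicus as the target, read by paw edema, with stated times of 1 h and 3 h, at a dose of 70 mg/kg by the oral route (on this read-out lower numbers stand for less inhibition and higher numbers for more inhibition at the one dose given (going by the name of the read-out)), compound 1 gives 78.8%, the second highest of the three numbers. Its nearest neighbour is compound 2 with 80%, and the step of a number 1.2 percentage points higher from compound 1 to compound 2 (within the scatter) lies within the scatter. Compound 3 gives 74.2%, and the step of a number 4.6 percentage points lower from compound 1 to compound 3 (within the scatter) is likewise within the scatter. The three compounds therefore read as one level.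

Compound 4 `Sc1nnc(Nc2nc3ccc(Cl)cc3s2)o1` is not yet measured. It differs from compound 1 as follows: sulfanyl in place of phenyl on an aromatic carbon. The measured steps all exchange one large group for another at the same place; none removes the ring altogether, so none bears directly on this change. Among the measured compounds shown here, the steps from compound 1 to compounds 2 and 3 show only that two other large groups at this place leave the read-out within the scatter. For the measured compounds named here, with no measured step of this kind, the expectation is a moderate fall, a number 16.8 percentage points lower from compound 1 to compound 4 (beyond the scatter), with a wide range. Compound 4 is thus estimated at 62%, between 42% and 78%.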

Compound 4, a percentage reported as inhibition, in the whole organism at one dose (the size of the read-out at that dose, not a potency): 61.7%
The estimate for compound 4 lay 0.3 percentage points above the measured number; low and high end bracket the measured number.
By their numbers in this assay, from the lowest: compound 4; then compounds 3, 1 and 2 (each within the scatter of the next).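

Sulfanyl is the first group at this aromatic carbon to shift this assay beyond the scatter: a number 17.1 percentage points lower from compound 1 to compound 4 (beyond the scatter), and the same holds against the other two groups, a number 12.5 percentage points lower from compound 3 to compound 4 (beyond the scatter) and a number 18.3 percentage points lower from compound 2 to compound 4 (beyond the scatter). Phenyl, 2,4-dichlorophenyl and phenoxy thus read as one level, while sulfanyl, which has no ring, stands apart; even so, compound 4 still gives 61.7%, so the inhibition does not vanish when no ring sits at this place. The data shown give no reason for this fall.

Among the compounds shown here, with only one ringless group at this place, it stays open whether the fall follows the loss of the ring or the sulfanyl itself; an amine or a methyl group on the same carbon would separate the two. As far as these compounds go, how the four compounds compare at other doses also stays open.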